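The compounds below may be only part of what the source reports. "The series", "measured", "known", "first", "only" and "open" are said of these compounds alone.

Measured so far:
- compound 1, `COc1cc2c(Oc3ccc(NC(=O)c4nn(-c5ccccc5)ccc4=O)cc3)ccnc2cc1OCCCC(=O)NO`: 940 nM
- compound 2, `COc1cc2c(Oc3ccc(NC(=O)c4nn(-c5ccccc5)cc(C)c4=O)cc3)ccnc2cc1OCCCCCCC(=O)NO`: 150 nM
- compound 3, `COc1cc2c(Oc3ccc(NC(=O)c4nn(-c5cccc(C)c5)cc(C)c4=O)cc3)ccnc2cc1OCCCCCCC(=O)NO`: 370 nM

All three compounds share the same core and the same hydroxamic acid tail, and all were tested in a functional assay on HCT-116 cells (Homo sapiens) for inhibition, read by MTT assay, with a stated time of 72 h; a higher number here means a weaker inhibitor, a lower number a stronger inhibitor. Compound 3 has the second highest number of the three: compound 2 sits nearest, with a lower number, and compound 1 furthest, with a higher one, both differences lying beyond the scatter. Among the measured compounds shown here, the one measured step that involves compound 3 is a 2.5-fold higher number from compound 2 to compound 3 (0.39 log units; beyond the scatter), a methyl in place of hydrogen on an aromatic carbon of the phenyl group.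

Compound 4, `COc1cc2c(Oc3ccc(NC(=O)c4nn(-c5ccc(C)cc5C)cc(C)c4=O)cc3)ccnc2cc1OCCCCCCC(=O)NO`, has not yet been measured. It differs from compound 3 in one place: 2,4-dimethylphenyl in place of 3-methylphenyl on an aromatic nitrogen. This change again adds a methyl to the same phenyl group, while also shifting where the methyl groups sit. For the measured compounds named here, the step from compound 2 to compound 3 is the only guide here, and it shows that adding a methyl to this ring raised the number modestly. A second methyl is expected to behave similarly or to lie within the scatter, so the step of a 1.5-fold higher number from compound 3 to compound 4 (0.17 log units; within the scatter) is expected to be small and upward. For compound 4 the estimate in this assay is 550 nM, with a likely range from 220 nM to 1400 nM.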

Compound 4, half-maximal inhibitory concentration: 440 nM
Compound 4: the middle estimate sits 1.3-fold (0.10 log units) above what was measured; the measured number falls inside the stated range.
By their numbers in this assay, from the lowest: compound 2; then compounds 3 and 4 (each within the scatter of the next); then compound 1.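

In this assay, replacing 3-methylphenyl with 2,4-dimethylphenyl on the aromatic nitrogen gives a 1.2-fold higher number from compound 3 to compound 4 (0.08 log units; within the scatter): this ring accepts a second methyl and a new arrangement of its methyl groups with no change that can be told from the scatter. Against the plain phenyl, the same 2,4-dimethylphenyl group gives a 2.9-fold higher number from compound 2 to compound 4 (0.47 log units; beyond the scatter), a step close in size to the one seen with a single methyl, a 2.5-fold higher number from compound 2 to compound 3 (0.39 log units; beyond the scatter), so each methyl-bearing ring carries a higher number than the plain phenyl, and the second methyl adds nothing readable beyond the first. No measurement shown here explains why methyl groups on this ring go with a higher number.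

Still open, going by these compounds, is whether that higher number depends on where a methyl sits on the ring or only on a methyl being there at all, since the two compounds with methyl groups on this ring cannot separate those possibilities. Also open, on these data alone, is how a group other than methyl on this ring, such as a methoxy group, a fluorine atom or an amine, would move the number, whether back towards the plain phenyl or further from it.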